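Looking ahead to compound 3 in the mouse

A few compounds are considered here, and "the series" means these few. Any claim that something is new, unique, unknown or untested is made for them only; others in the source may bear on it.

Compound 1 `CC1=C(CN2CC(C(=O)O)C2)CCc2cc(OCc3ccc4ccccc4c3)ccc21` gives "not determined" (no result reported)
Compound 2 `CC1=C(CN2CC(C(=O)O)C2)CCc2cc(OCC3Cc4ccccc4C3)ccc21` gives > 1 mg/kg

In a functional assay on the whole organism (strain BALB/c) with Mus musculus as the target, with a stated time of 4 h (on this read-out higher numbers stand for an effect only at larger amounts of compound and lower numbers for an effect already at smaller amounts), compound 2 holds a limit and not a number (> 1 mg/kg). Within the data shown here, compound 1 has no result ("not determined" (no result reported)), so the series offers no measured step. The limit is the only anchor so far (the limit of > 1 mg/kg in this assay, at which 1 of the 2 values shown sits).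

The next compound, compound 3 `CC1=C(CN2CC(C(=O)O)C2)CCc2cc(OCc3ccc(CC(C)C)cc3)ccc21`, keeps the core of compound 2 and differs at one place, on a saturated chain carbon bound to an oxygen on an aromatic ring (4-isobutylphenyl in place of 2,3-dihydro-1H-inden-2-yl on a saturated chain carbon bound to an oxygen on an aromatic ring).

Among the measured compounds shown here, with no measured step to lean on, a moderate and uncertain shift towards an effect at smaller amounts is expected in this assay (an at least 1.6-fold lower number from compound 2 to compound 3 (0.22 log units; that floor lies within the scatter)). Compound 3 is expected at 0.6 mg/kg with an estimated range from 0.1 mg/kg to 3 mg/kg as the likely span.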

Compound 3, dose for half-maximal effect: 0.39 mg/kg
Compound 3: middle estimate off by 1.5-fold (0.19 log units), on the high side; low and high end bracket the measured number.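

At the saturated chain carbon bound to an oxygen on an aromatic ring, 4-isobutylphenyl in place of 2,3-dihydro-1H-inden-2-yl gives the series its first readable step in this assay, an at least 2.5-fold lower number from compound 2 to compound 3 (0.40 log units; beyond the scatter). This shows that the number in this assay responds to the group held at this position, and the step lies beyond the usual scatter. Its full size stays unknown because compound 2 holds a limit and not a number: the limit of > 1 mg/kg in this assay, at which 1 of the 3 values shown sits.

Among these compounds, the single change replaces the whole group, so the share of the isobutyl chain and of the phenyl ring cannot be told apart. Open too, as far as these compounds go, is whether a plain phenyl, or a 4-trifluoromethylphenyl in place of 4-isobutylphenyl, would keep the number of compound 3 at 0.39 mg/kg.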